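A few compounds are considered here, and "the series" means these few. Any claim that something is new, unique, unknown or untested is made for them only; others in the source may bear on it.

Measured in a functional assay on SW480 cells (Homo sapiens) for antiproliferative activity, read by sulforhodamine B assay, with a stated time of 48 h (a higher number here means a weaker inhibitor, a lower number a stronger inhibitor), the compounds give these values:
compound 1 (`COc1cccc(/C=C/C(=O)/C=C(O)/C=C/c2cccc(OC)c2OC)c1OC`) gives 12100 nM
compound 2 (`COc1ccc(OC)c(/C=C/C(=O)/C=C(O)/C=C/c2cc(OC)ccc2OC)c1`) gives 15600 nM
compound 3 (`COc1ccc(C=C(C(=O)/C=C/c2cccc(OC)c2OC)C(=O)/C=C/c2cccc(OC)c2OC)cc1OC`) gives 410 nM

Compound 3 holds the lowest number of the three, and its 410 nM lies beyond the scatter from both compound 1 and compound 2. Compound 4 (`COc1cccc(C=C(C(=O)/C=C/c2cccc(OC)c2OC)C(=O)/C=C/c2cccc(OC)c2OC)c1OC`) has not yet been measured. It differs from compound 3 on a double-bonded chain carbon bound to a double-bonded chain carbon (2,3-dimethoxyphenyl in place of 3,4-dimethoxyphenyl on a double-bonded chain carbon bound to a double-bonded chain carbon). Compound 1 at 12100 nM and compound 2 at 15600 nM lie within the scatter of each other, so only a small step towards a higher number, near the scatter, is expected in this assay here. The estimated change is a 1.6-fold higher number from compound 3 to compound 4 (0.20 log units; within the scatter) and would remain modest. For compound 4 the estimated value is 650 nM with a range of 250 nM to 1800 nM expected.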

Compound 4, half-maximal inhibitory concentration: 590 nM
Estimate against measurement, compound 4: 1.1-fold (0.04 log units) above, within the range that was stated.
By their numbers in this assay, from the lowest: compounds 3 and 4 (each within the scatter of the next); then compounds 1 and 2 (each within the scatter of the next).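

Within the data shown here, compound 3 and compound 4 are the first pair here that differ in one place, and in this assay the swap of 2,3-dimethoxyphenyl for 3,4-dimethoxyphenyl on a double-bonded chain carbon bound to a double-bonded chain carbon gives a 1.4-fold higher number from compound 3 to compound 4 (0.16 log units; within the scatter). At this position, the two dimethoxyphenyl groups therefore cannot be told apart in this assay. As far as these compounds go, whether a phenyl group carrying an amine or a carboxylic acid would be tolerated there remains open. Nothing given here explains the result.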